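Removal of the methoxy group from compound 2

The compounds below may be only part of what the source reports. "The series", "measured", "known", "first", "only" and "open" are said of these compounds alone.

Two members of the series have been tested in a functional assay on the whole organism (strain albino) with Mus musculus as the target, with a stated time of 4 h; on this read-out higher numbers stand for an effect only at larger amounts of compound and lower numbers for an effect already at smaller amounts. Compound 1 `Cc1ccc(/C=C2/N=C(c3ccccc3)N(C(=O)COc3ccccc3)NC2=O)cc1` gives 300 mg/kg in this assay. Compound 2 `COc1ccc(/C=C2/N=C(c3ccccc3)N(C(=O)c3ccc(Cl)cc3)NC2=O)cc1` carries a 4-chlorobenzoyl group and a methoxy group in place of the phenoxyacetyl and methyl groups of compound 1. In this assay, for the measured compounds named here, compound 2 is recorded as "not active" (no number reported), so no single number stands for compound 2 and no step between the two measured compounds can be counted; what the two values show is only that compound 1 has a measurable dose whereas compound 2 has none.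

Compound 3 `O=C1NN(C(=O)c2ccc(Cl)cc2)C(c2ccccc2)=N/C1=C/c1ccccc1` differs from compound 2 by hydrogen in place of methoxy on an aromatic carbon. Going by the values given here, no measured step of this kind exists, so the size and direction of the change in this assay cannot be read from the data; with compound 2 giving "not active" (no number reported), the nearest reference is an outcome without a number. Compound 3 is therefore expected to show either no measurable effect or a dose in this assay around 400 mg/kg, estimated within 150 mg/kg to 1000 mg/kg.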

Compound 3, dose for half-maximal effect: 300 mg/kg
Compound 3: middle estimate off by 1.3-fold (0.12 log units), on the high side, within the range that was stated.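

In this assay, for the compounds shown here, compound 3 gives 300 mg/kg, whereas compound 2 is recorded as "not active" (no number reported), so no step between compound 2 and compound 3 can be read. The compounds shown leave open how far the change from 4-methoxyphenyl to phenyl alone shifts this read-out. No further data bearing on this result are at hand.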